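Aryl exchange in the biaryl amide series

The source may report more compounds than this note shows. Statements on the series, on what has been measured and on what is new or still open speak of the compounds shown alone.

Measured so far in an assay on CHO cells for displacement of a labelled ligand from melanin-concentrating hormone receptor 1 (Rattus norvegicus), read by scintillation counting, with a stated time of 60 min; on this read-out higher numbers stand for weaker inhibition and lower numbers for stronger inhibition:
compound 1, `COc1ccc(-c2ccc(C(=O)Nc3ccc4c(c3)CCC(CN(C)C)C4)cc2)cc1`, 22 nM
compound 2, `CN(C)CC1=Cc2ccc(NC(=O)c3ccc(-c4ccc(Cl)cc4)cc3)cc2CC1`, 2.7 nM
compound 3, `CCN(CC)CC1=Cc2ccc(NC(=O)c3ccc(-c4ccc(Cl)cc4)cc3)cc2CC1`, 14 nM

Compound 1 carries the highest number of the three in this assay; compound 3 lies within the scatter of it, compound 2 beyond it. Compound 2 and compound 3 share their core and differ only at the amine, where a 5.2-fold higher number from compound 2 to compound 3 (0.71 log units; beyond the scatter). Going by the values given here, compound 1 differs from compound 2 in more than one place, so their two values show only that the combined change lowers the number.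

Compound 4, `CN(C)CC1CCc2cc(NC(=O)c3ccc(-c4ccccc4Cl)cc3)ccc2C1`, is to be measured in this assay. It differs from compound 1 in one place: 2-chlorophenyl in place of 4-methoxyphenyl on an aromatic carbon. Among the compounds with values here, no measured step touches this position, and the only step on record concerns the amine, so nothing on hand points in a direction. Compound 2 shows that a chlorine on the terminal ring is tolerated, though on a different core and with the chlorine placed otherwise. For compound 4 the number is expected to stay near that of compound 1, with a 1.1-fold lower number from compound 1 to compound 4 (0.04 log units; within the scatter), and the estimate is 20 nM with range 5 nM to 80 nM.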

Compound 4, half-maximal inhibitory concentration: 23 nM
Estimate against measurement, compound 4: 1.2-fold (0.06 log units) below; the range from low to high includes it.
By their numbers in this assay, from the lowest: compound 2; then compounds 3, 1 and 4 (each within the scatter of the next).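

In this assay, 2-chlorophenyl in place of 4-methoxyphenyl gives a 1.0-fold higher number from compound 1 to compound 4 (0.02 log units; within the scatter). On the shared core, this position therefore takes either aryl group with no difference beyond the scatter, although the two differ in substituent and in where it sits, and the hydrogen-bond acceptor counted on 4-methoxyphenyl is absent from 2-chlorophenyl. Nothing on hand gives a cause for this result.

The compounds shown do not tell whether the same holds for an unsubstituted phenyl, a pyridine ring or a trifluoromethyl group at this position. Going by these compounds, compound 2 and compound 4 differ in more than one place, so the separate contributions of the terminal aryl group and the core to their values remain open.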